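A few compounds are considered here, and "the series" means these few. Any claim that something is new, unique, unknown or untested is made for them only; others in the source may bear on it.

Measured compounds:
compound 1 `CC(C)n1cnc2c(Nc3ccccc3)nc(NCOCc3ccc(C(=O)Nc4ccccc4N)cc3)nc21` gives 6.85%
compound 2 `CC(C)n1cnc2c(Nc3ccccc3)nc(NCOCc3ccc(/C=C/C(=O)Nc4ccccc4N)cc3)nc21` gives 2.53%
compound 3 `CC(C)n1cnc2c(Nc3cccc(Cl)c3)nc(NCOCc3ccc(C(=O)Nc4ccccc4N)cc3)nc21` gives 7.12%

All three were tested in a functional assay on HCT-116 cells (Homo sapiens) for antiproliferative activity, read by CCK-8 assay, with a stated time of 72 h, tested at 2 uM; a higher number here means a stronger effect of the compound at the concentration tested, a lower number a weaker effect. The numbers are small and sit within the scatter of one another, so none of the three can be called stronger or weaker. Compound 1 stands second highest of the three: its nearest neighbour is compound 3, with a number 0.3 percentage points higher from compound 1 to compound 3 (within the scatter), and its furthest is compound 2, with a number 4.3 percentage points lower from compound 1 to compound 2 (within the scatter).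

Compound 4 `Nc1ccccc1NC(=O)c1ccc(COCNc2nc(Nc3ccccc3)c3ncn(C4CCCC4)c3n2)cc1` differs from compound 1 in one place: cyclopentyl in place of isopropyl on an aromatic nitrogen. Neither measured step touches this position, and both measured steps stayed within the scatter, so there is no basis for expecting a change beyond it. The expected step is a number 0.2 percentage points higher from compound 1 to compound 4 (within the scatter). Compound 4 is therefore estimated at 7%, with a range from 0% to 18%.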

Compound 4, a percentage reported as inhibition, at one concentration (the size of the read-out at that concentration, not a potency): 75.2%
Compound 4: the middle estimate sits 68.2 percentage points below what was measured; the measured number lies above the stated range.
By their numbers in this assay, from the lowest: compounds 2, 1 and 3 (each within the scatter of the next); then compound 4.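

On the aromatic nitrogen of the five-membered ring, a single change of group moves the read-out sharply: cyclopentyl in place of isopropyl gives a number 68.4 percentage points higher from compound 1 to compound 4 (beyond the scatter). The two earlier steps, made elsewhere on the molecule, stayed within the scatter, so this is the first position shown where the group clearly matters. Nothing at hand explains the jump.

Still open, on these data alone, is whether the ring itself counts or just the larger number of carbons, which a cyclohexyl group or an open pentyl chain on this nitrogen would help separate. Also open, as far as these compounds go, is whether the chloro change of compound 3 would behave the same with cyclopentyl present.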